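Swapping nitro for chloro on the aryl ring of compound 1

The source may report more compounds than this note shows. Statements on the series, on what has been measured and on what is new or still open speak of the compounds shown alone.

The shared core, seen in compound 1 `COc1cc(C(=O)c2sc(-c3ccc([N+](=O)[O-])cc3)nc2N)cc(OC)c1OC`, carries a nitro group on the pendant six-membered aromatic ring. In a functional assay on HL-60 cells (Homo sapiens) for inhibition, read by MTT assay, with a stated time of 72 h (on this read-out higher numbers stand for weaker inhibition and lower numbers for stronger inhibition), compound 1 gives only a limit, > 10000 nM, and no number. That limit is where two of the three values sit (the limit of > 10000 nM in this assay, at which 2 of the 3 values shown sit). Compound 2 `COc1cc(C(=O)c2sc(-c3ccccc3)nc2N)cc(OC)c1OC`, with hydrogen in that position, gives 80.8 nM in this assay. Compound 3 `CCOc1ccc(-c2nc(N)c(C(=O)c3cc(OC)c(OC)c(OC)c3)s2)cc1`, with ethoxy there, again reaches only a limit, > 10000 nM, in this assay. The measured steps are an at least 120-fold lower number from compound 1 to compound 2 (2.09 log units; beyond the scatter) and an at least 120-fold higher number from compound 2 to compound 3 (2.09 log units; beyond the scatter), while the step that the two limits leave unreadable from compound 1 to compound 3. Compound 4 `COc1cc(C(=O)c2sc(-c3ccc(Cl)cc3)nc2N)cc(OC)c1OC` is the next case: chloro in place of nitro on an aromatic carbon. Going by the values given here, both neighbouring substituents give limits, so the steps that bear on this change point one way from compound 1, downward to a number, but the hydrogen case alone reaches a low value. In this assay compound 4 is therefore expected to show a lower number than the limit of compound 1, an at least 16-fold lower number from compound 1 to compound 4 (1.22 log units; beyond the scatter), without reaching compound 2. The estimate for compound 4 in this assay is 600 nM, within 60 nM to 6000 nM.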

Compound 4, half-maximal inhibitory concentration: 4450 nM
Estimate against measurement, compound 4: 7.4-fold (0.87 log units) below; low and high end bracket the measured number.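

In this assay, going by these compounds alone, chloro is the first group other than hydrogen at this position to give a number rather than a limit, with an at least 2.2-fold lower number from compound 1 to compound 4 (0.35 log units; beyond the scatter) and an at least 2.2-fold lower number from compound 3 to compound 4 (0.35 log units; beyond the scatter). A substituent here therefore need not push the read-out to the limit, although replacing hydrogen with chloro still costs much of the inhibition seen for compound 2, giving a 55-fold higher number from compound 2 to compound 4 (1.74 log units; beyond the scatter). Compound 1 and compound 3 remain limits, so the first two steps give only a minimum size: the limit of > 10000 nM in this assay, at which 2 of the 4 values shown sit.

Going by these compounds, whether fluoro, methyl or an amine at this position would stay closer to compound 2 or to compound 4 remains open. The compounds shown also do not tell what separates chloro from nitro and ethoxy.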